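The source may hold more compounds than are shown below. What is called first, only, known or untested is meant among the compounds shown, and "the series" means these compounds.

Compound 1: `CS(=O)(=O)N1CCc2c(c(-c3ccc(C(F)(F)F)cc3)nn2CC(O)CN2CCC(c3csc4cc(F)ccc34)CC2)C1`, 180 nM
Compound 2: `CS(=O)(=O)N1CCc2c(c(-c3ccc(C(F)(F)F)cc3)nn2CC(O)CN2CCC(c3c[nH]c4cc(Cl)ccc34)CC2)C1`, 29 nM

In an assay on isolated protein for inhibition of cathepsin S (Homo sapiens) (on this read-out higher numbers stand for weaker inhibition and lower numbers for stronger inhibition), compound 2 has the lower of the two numbers shown, and the gap to compound 1 is the step of a 6.2-fold lower number from compound 1 to compound 2 (0.79 log units; beyond the scatter). Compound 3, `CS(=O)(=O)N1CCc2c(c(-c3ccc(C(F)(F)F)cc3)nn2CC(O)CN2CCC(c3c[nH]c4c(Cl)cccc34)CC2)C1`, keeps every atom of compound 2 but joins them differently: 7-chloro-1H-indol-3-yl in place of 6-chloro-1H-indol-3-yl on a saturated ring carbon. For the measured compounds named here, only one measured step concerns this part of the molecule, the step from compound 1 to compound 2, and it exchanged the whole aromatic group rather than shifting a chlorine within it, so it is a loose guide at best. Going by the values given here, no measured pair shows what moving the chlorine does. The expectation is therefore a small step of a 1.9-fold higher number from compound 2 to compound 3 (0.28 log units; within the scatter) in this assay, more likely towards a higher number than a lower one, and possibly none beyond the scatter. Compound 3 is expected to give about 55 nM, with a range from 15 nM to 220 nM.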

Compound 3, half-maximal inhibitory concentration: 34 nM
Compound 3: middle estimate off by 1.6-fold (0.21 log units), on the high side; the range from low to high includes it.
By their numbers in this assay, from the lowest: compounds 2 and 3 (each within the scatter of the next); then compound 1.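

In this assay, for the compounds shown here, the pair of compound 2 and compound 3 is the first to isolate where the chlorine sits on the indole, and the outcome is a 1.2-fold higher number from compound 2 to compound 3 (0.07 log units; within the scatter), so 6-chloro-1H-indol-3-yl and 7-chloro-1H-indol-3-yl cannot be told apart here. The second chloroindole also differs from the 6-fluoro-1-benzothiophen-3-yl group by a margin beyond the scatter, with a 5.3-fold lower number from compound 1 to compound 3 (0.72 log units; beyond the scatter), so the earlier gain does not depend on one chlorine placement. No independent measurement bears on the reason for these numbers.

On these data alone, both steps from compound 1 exchange the ring system and the halogen together, so their separate contributions remain unknown. Also open, as far as these compounds go, is how the unsubstituted 1H-indol-3-yl group, or a methoxy or nitrile in place of the chlorine, would compare.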